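A few compounds are considered here, and "the series" means these few. Any claim that something is new, unique, unknown or untested is made for them only; others in the source may bear on it.

Measured in a functional assay for inhibition, with Rattus norvegicus as the target; a lower number here means a stronger inhibitor, a higher number a weaker inhibitor:
- Compound 1 `CCc1c(CC)c(OC(C)=O)c2ccccc2c1OC`: 400 nM
- Compound 2 `CCc1c(CC)c(OC)c2c(OC)cccc2c1OC(C)=O`: 890 nM

Of these two compounds, compound 2 has the higher number, so it is the weaker inhibitor in this assay. The gap is modest: a 2.2-fold higher number from compound 1 to compound 2 (0.35 log units; beyond the scatter). Compound 3 `CCc1c(CC)c(OC)c2c(C)cccc2c1OC(C)=O` keeps the core of compound 2 and carries one change, methyl in place of methoxy on an aromatic carbon. Within the data shown here, only one measured step bears on this, the methoxy in place of hydrogen that gave a 2.2-fold higher number from compound 1 to compound 2 (0.35 log units; beyond the scatter). Among the measured compounds shown here, no measured compound shows what a methyl group does here, so the guide is thin. Losing the methoxy group may undo part of that step, so a small move towards a lower number seems likely. The expected change is a 1.5-fold lower number from compound 2 to compound 3 (0.17 log units; within the scatter), which may not clear the usual scatter. For compound 3 the estimated value is 600 nM, with an expected range of 220 nM to 1600 nM.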

Compound 3, half-maximal inhibitory concentration: 830 nM
Estimate against measurement, compound 3: 1.4-fold (0.14 log units) below; measured number inside the range.
By their numbers in this assay, from the lowest: compound 1; then compounds 3 and 2 (each within the scatter of the next).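

In this assay, among these compounds, methyl in place of methoxy on this aromatic carbon gives a 1.1-fold lower number from compound 2 to compound 3 (0.03 log units; within the scatter) and so does not separate the two groups, something the earlier compounds could not show. Methyl in place of hydrogen gives a 2.1-fold higher number from compound 1 to compound 3 (0.32 log units; beyond the scatter) and stands beside a 2.2-fold higher number from compound 1 to compound 2 (0.35 log units; beyond the scatter), so with either group on this carbon the number sits above that of compound 1, and the oxygen of the methoxy group is not required for that shift. Nothing available explains why the two groups behave alike here.

Going by these compounds, whether the same holds for a larger group at this position, such as a longer chain, stays open. So does the outcome with an amine or a chlorine atom there, including whether any group could bring the number below that of compound 1.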